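A few compounds are considered here, and "the series" means these few. Any claim that something is new, unique, unknown or untested is made for them only; others in the source may bear on it.

Working notes on the series built on the shared core of compound 1, `CSc1ccc(F)cc1NCC1=NCCN1`, where the substituent pattern on the aromatic ring is varied and agonist potency is read in a functional assay for agonist activity at Alpha-1D adrenergic receptor (Homo sapiens); a higher number here means that more compound is needed for the effect, a lower number that less compound is needed.

Compound 1 gives 21.9 nM. Within the data shown here, compound 2, `CSc1ccc(C)cc1NCC1=NCCN1`, gives 0.912 nM; the step of a 24-fold lower number from compound 1 to compound 2 (1.38 log units; beyond the scatter) is the only measured step with a number at both ends. Compound 3, `CS(=O)(=O)c1ccc(C(F)(F)F)cc1NCC1=NCCN1`, returns only a limit in this assay, < 100000 nM, so its standing against compounds 1 and 2 cannot be placed on a number; the limit is recorded as the limit of < 100000 nM in this assay, at which 1 of the 3 values shown sits.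

Compound 4, `CSc1ccc(C(F)(F)F)cc1NCC1=NCCN1`, differs from compound 3 by methylsulfanyl in place of methylsulfonyl on an aromatic carbon. Among the measured compounds shown here, no measured step bears directly on this change, and the start point is a limit rather than a value, so no computed step exists between compound 3 and compound 4. Compounds 1 and 2 show that the methylsulfanyl-bearing core reaches nanomolar potency in this assay, so compound 4 is expected near them rather than at the limit. The estimate for compound 4 is 40 nM, with a range from 4 nM to 400 nM, which would mean an expected step that the limit leaves unreadable from compound 3 to compound 4.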

Compound 4, half-maximal effective concentration: 43.7 nM
Compound 4: middle estimate off by 1.1-fold (0.04 log units), on the low side; the range from low to high includes it.
By their numbers in this assay, from the lowest: compound 2; then compounds 1 and 4 (each within the scatter of the next).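

In this assay, with methylsulfanyl held constant, the aromatic carbon that carries fluoro or methyl now has a third measured group, and trifluoromethyl in place of methyl gives a 48-fold higher number from compound 2 to compound 4 (1.68 log units; beyond the scatter). Trifluoromethyl in place of fluoro gives a 2.0-fold higher number from compound 1 to compound 4 (0.30 log units; within the scatter), so among these three groups only methyl stands apart, and these two compounds are not ordered. The change from methylsulfonyl to methylsulfanyl cannot be read as a step; compound 3 stands only as a limit: the limit of < 100000 nM in this assay, at which 1 of the 4 values shown sits.

From the compounds shown here alone, whether the low number seen with methyl extends to a longer chain such as ethyl, or to a methoxy group or an amine on the same carbon, remains open. Methylsulfonyl appears here only with trifluoromethyl, so its standing alongside methyl or fluoro also remains open.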